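Adding one fluoro to a weak compound

The source may hold more compounds than are shown below. What is called first, only, known or untested is meant among the compounds shown, and "the series" means these compounds.

compound 1 `COc1ccc(-c2nnc(COc3ccc(C#N)cc3OC)o2)cc1`: 11100 nM
compound 2 `c1ccc(-c2nnc(COc3ccc(-c4nnco4)cc3)o2)cc1`: > 50000 nM

Both results come from a functional assay on MCF7 cells (Homo sapiens) for cytotoxicity, read by MTT assay, with a stated time of 48 h; on this read-out higher numbers stand for weaker inhibition and lower numbers for stronger inhibition. Compound 1 has a true measured number and compound 2 does not. For compound 2 the entry > 50000 nM is a limit of the assay and not a number.

Compound 3 `Fc1ccc(-c2nnc(COc3ccc(-c4nnco4)cc3)o2)cc1` is compound 2 with one small edit: fluoro in place of hydrogen on an aromatic carbon. In words, fluoro takes the place of hydrogen on an aromatic carbon, para to a large group, so phenyl becomes 4-fluorophenyl.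

Among the compounds with values here, no measured pair of compounds shows what such an edit does in this assay, so the expectation is modest: no step beyond the usual scatter, and no preferred direction. The expectation rests on compound 2 with its reading of > 50000 nM as a limit. The estimated change, a number no higher from compound 2 to compound 3 (the limit leaves the size open), is therefore expected to be small. Compound 3 may well be reported only as a limit too. As a number, compound 3 is expected near 50000 nM, with an estimated range from 20000 nM to 100000 nM.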

Compound 3, half-maximal inhibitory concentration: 35600 nM
Compound 3: middle estimate off by 1.4-fold (0.15 log units), on the high side, and the stated range covers the measured number.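

In this assay, the change from phenyl to 4-fluorophenyl gives an at least 1.4-fold lower number from compound 2 to compound 3 (0.14 log units; that floor lies within the scatter). Within the data shown here, this is the first step that can be read at all, and it comes with a true number on one side, since compound 3 has a measured value where compound 2 has none. Even so, the step shows only a floor, which by itself does not establish a real gain from fluoro at this position, and its true size stays unknown because compound 2 is reported only as a limit, not as a number: the limit of > 50000 nM in this assay, at which 1 of the 3 values shown sits.

The compounds shown leave open whether another group in the same place, such as chloro, an amine or a carboxylic acid, would give a similar reading or a clearly different one, and so whether anything about fluoro itself matters here. From the compounds shown here alone, compound 1 differs from compound 3 in more than one place, so its value says nothing about this position, and how much of the gap between those two compounds could be traced to the aromatic ring carrying fluoro remains unknown.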